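The source may report more compounds than this note shows. Statements on the series, on what has been measured and on what is new or still open speak of the compounds shown alone.

For the measured compounds named here, in an assay on HEK293 cells for positive allosteric modulation of metabotropic glutamate receptor 5 (Homo sapiens), read by FLIPR (on this read-out lower numbers stand for an effect already at smaller amounts and higher numbers for an effect only at larger amounts of compound), compound 2 `CC1CCN(C(=O)N2CC(c3nc(-c4cccc(Cl)c4)no3)C2)CC1` gives 865 nM and stands at one end of the three numbers measured so far. Compound 1 `CC1CCC(C(=O)N2CC(c3nc(-c4cccc(Cl)c4)no3)C2)CC1` gives 1500 nM in this assay, and the step of a 1.7-fold lower number from compound 1 to compound 2 (0.24 log units; within the scatter) does not separate the two. Compound 3 `O=C(c1ccc(F)cc1)N1CC(c2nc(-c3cccc(F)c3)no2)C1` gives 2400 nM in this assay, and its gap to compound 2 lies beyond the scatter. Compound 4 `CC1CN(C(=O)N2CC(c3nc(-c4cccc(Cl)c4)no3)C2)CC(C)O1` has not yet been measured. It differs from compound 2 at one place: 2,6-dimethylmorpholin-4-yl in place of 4-methylpiperidin-1-yl on a carbonyl carbon. Going by the values given here, the only measured step at this carbonyl carbon is the one from compound 1 to compound 2, where one six-membered ring replaced another and the number moved by a 1.7-fold lower number from compound 1 to compound 2 (0.24 log units; within the scatter), within the scatter. Among the compounds with values here, no measured pair shows an oxygen entering such a ring, so there is nothing to anchor a larger move. Compound 4 is therefore expected to give about 1000 nM in this assay, between 400 nM and 2500 nM. This expectation means a step of a 1.2-fold higher number from compound 2 to compound 4 (0.06 log units; within the scatter), none beyond the scatter.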

Compound 4, half-maximal effective concentration: > 10000 nM
Compound 4 was reported as a limit; the forecaster's own chance of this, stated with the estimate: 5%; middle value at least 10-fold (1.00 log units) away from the limit.
By their numbers in this assay, from the lowest: compounds 2, 1 and 3 (each within the scatter of the next, the first and the last beyond it). At a limit, above all of these: compound 4.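

In this assay compound 4 is reported only as a limit, not as a number: the limit of > 10000 nM in this assay, at which 1 of the 4 values shown sits.

At this carbonyl carbon, the exchange of one six-membered ring for another had stayed within the scatter, but this position does not accept every such ring: the change to 2,6-dimethylmorpholin-4-yl gives an at least 11-fold higher number from compound 2 to compound 4 (1.06 log units; beyond the scatter) and an at least 6.6-fold higher number from compound 1 to compound 4 (0.82 log units; beyond the scatter). The change brings in the ring oxygen and the methyl groups together, and the data do not tell which of them carries the shift.

On these data alone, it remains open whether a plain morpholin-4-yl, without the methyl groups, or a 3,5-dimethylpiperidin-1-yl, without the ring oxygen, would stay close to compound 2. As far as these compounds go, how far the true value of compound 4 lies beyond its limit also remains open.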